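Compound 4: 4-ethylphenyl on the sulfonyl sulfur

The source may report more compounds than this note shows. Statements on the series, on what has been measured and on what is new or still open speak of the compounds shown alone.

In an ADME assay on HEK293 cells (Homo sapiens) for cytotoxicity, read by resazurin assay, with a stated time of 48 h (a lower number here means that less compound is tolerated, a higher number that more compound is tolerated), compound 1 (`O=S(=O)(Nc1ccc(-c2nc3ccccc3o2)cc1)c1ccccc1Cl`) gives > 100000 nM, which is a limit. Compound 2 (`O=S(=O)(Nc1ccc(-c2nc3ccccc3o2)cc1)c1cccc(O)c1`) gives > 100000 nM, also a limit. Compound 3 (`COc1ccccc1S(=O)(=O)Nc1ccc(-c2nc3ccccc3o2)cc1`) gives > 100000 nM, again a limit, so compound 3 has no number to start from.

The next structure, compound 4 (`CCc1ccc(S(=O)(=O)Nc2ccc(-c3nc4ccccc4o3)cc2)cc1`), has 4-ethylphenyl in place of 2-methoxyphenyl on a sulfonyl sulfur.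

Among the compounds with values here, three measured steps bear on this change: a step that the two limits leave unreadable from compound 1 to compound 2, a step that the two limits leave unreadable from compound 1 to compound 3 and a step that the two limits leave unreadable from compound 2 to compound 3. None of them gives a size, and none brings in 4-ethylphenyl. Within the data shown here, the series so far is summed up by the limit of > 100000 nM in this assay, at which 3 of the 3 values shown sit. On that evidence, no step beyond the scatter is expected in this assay, in either direction.

The expected step is a number no higher from compound 3 to compound 4 (the limit leaves the size open). For compound 4 the estimate is 100000 nM, with an expected range of 40000 nM to 200000 nM. A report as a limit is the most likely outcome.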

Compound 4, half-maximal cytotoxic concentration: 82000 nM
The estimate for compound 4 lay 1.2-fold (0.09 log units) above the measured number; the range from low to high includes it.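

In this assay, within the data shown here, compound 4, with 4-ethylphenyl on the sulfonyl sulfur, is the first compound here to give a number rather than a limit, so a change at this place can bring the read-out within measurable range. Set against the earlier limits, the replacements give an at least 1.2-fold lower number from compound 3 to compound 4 (0.08 log units; that floor lies within the scatter), an at least 1.2-fold lower number from compound 2 to compound 4 (0.08 log units; that floor lies within the scatter) and an at least 1.2-fold lower number from compound 1 to compound 4 (0.08 log units; that floor lies within the scatter), so none of the three shows a step beyond the scatter. The steps among compounds 1, 2 and 3 cannot be read, and most of the series remains at the ceiling: the limit of > 100000 nM in this assay, at which 3 of the 4 values shown sit.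

The compounds shown do not separate the effect of the ethyl group from that of where it sits on the ring. They also leave open whether a longer chain, such as 4-butylphenyl, or an amine on this ring would give a clearly lower number.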